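Phenoxy in place of phenyl: expectation for compound 4

The source may report more compounds than this note shows. Statements on the series, on what has been measured and on what is new or still open speak of the compounds shown alone.

Measured in a functional assay on BXPC-3 cells (Homo sapiens) for inhibition, read by XTT assay, with a stated time of 72 h (a lower number here means a stronger inhibitor, a higher number a weaker inhibitor), so far:
- compound 1, `CC(=O)N1CCC[C@H]1COCCCCCCCCC/C=C/c1ccc(-c2ccccc2)cc1`, gives 56700 nM
- compound 2, `CC(=O)N1CCC[C@H]1COCCCCCCCCC/C=C/c1ccc(Oc2ccccc2)cc1`, gives 73300 nM
- compound 3, `CC(C)(C)OC(=O)NCC(=O)N1CCC[C@H]1COCCCCCC/C=C/c1ccc(-c2ccccc2)cc1`, gives 66700 nM

All three numbers sit close together in this assay, and none of the gaps between them goes beyond the usual scatter. Compound 1 and compound 2 share a core and differ in one place: phenoxy in place of phenyl on an aromatic carbon. The step that this made is a 1.3-fold higher number from compound 1 to compound 2 (0.11 log units; within the scatter), so the change left the number essentially where it was. Compound 3 carries a different core from compound 1; how the two cores differ is not broken down here.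

Compound 4, `CC(C)(C)OC(=O)NCC(=O)N1CCC[C@H]1COCCCCCC/C=C/c1ccc(Oc2ccccc2)cc1`, is not yet measured. It stands to compound 3 as compound 2 stands to compound 1: phenoxy in place of phenyl on an aromatic carbon. The place line reads the same word for word in both pairs, so this is the same change, made for the second time in the series. For the measured compounds named here, the only precedent is the pair of compound 1 and compound 2, whose step a 1.3-fold higher number from compound 1 to compound 2 (0.11 log units; within the scatter) lies within the scatter, and compound 3 itself sits within the scatter of both compound 1 and compound 2. On that basis a step of about a 1.2-fold higher number from compound 3 to compound 4 (0.08 log units; within the scatter) is expected from compound 3 to compound 4 in this assay, that is, no real movement. Compound 4 is accordingly estimated at 80000 nM in this assay, with a plausible range from 40000 nM to 160000 nM; the range is wide because the step of a 1.3-fold higher number from compound 1 to compound 2 (0.11 log units; within the scatter) rests on a single pair and the numbers themselves are weak.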

Compound 4, half-maximal inhibitory concentration: 80000 nM
For compound 4 middle estimate and measured number coincide at the digits printed; measured number inside the range.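

In this assay, phenoxy in place of phenyl on the core of compound 3 gives a 1.2-fold higher number from compound 3 to compound 4 (0.08 log units; within the scatter) and leaves the number essentially where it stood. This does not show that the two cores respond alike to changes in general: neither step moves the number beyond the scatter, so the agreement is between two steps without real movement, and it cannot say whether a change with a real effect on one core would carry over to the other. With only two pairs, the finding is limited to this one change on these two cores, where it carries over as a change that makes no measurable difference, and the two steps do not differ: the same change on two cores in this assay, a 1.3-fold higher number (0.11 log units; within the scatter) from compound 1 to compound 2 and a 1.2-fold higher number (0.08 log units; within the scatter) from compound 3 to compound 4, 1.1-fold (0.03 log units) apart, within the scatter of two such steps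

The compounds shown leave open whether any group at this place, on an aromatic carbon para to a large group, can move the number at all, for example an amine or a carboxylic acid in place of phenyl or phenoxy. Also open, from the compounds shown here alone, is whether phenoxy in place of phenyl would remain without effect on a core with a longer chain, or in a compound with a much lower number in this assay.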